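Compound 3 to compound 4: phenethyl on the triple bond

The source may report more compounds than this note shows. Statements on the series, on what has been measured and on what is new or still open speak of the compounds shown alone.

Measured in a functional assay on MIA PaCa-2 cells (Homo sapiens) for antiproliferative activity, read by MTT assay, with a stated time of 3 days; a lower number here means a stronger inhibitor, a higher number a weaker inhibitor:
- compound 1 `CCCCCCCCC#Cc1cn(C/C=C/CN2C(=O)c3ccccc3C2=O)c(=O)[nH]c1=O` gives > 100000 nM as a limit of the assay
- compound 2 `CCCCCC#Cc1cn(C/C=C/CN2C(=O)c3ccccc3C2=O)c(=O)[nH]c1=O` gives 60000 nM as a number
- compound 3 `CCCCCc1ccc(C#Cc2cn(C/C=C/CN3C(=O)c4ccccc4C3=O)c(=O)[nH]c2=O)cc1` gives 26000 nM as a number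

Compound 3 has the lower of the two actual numbers, and compound 2 is its nearest neighbour. The next structure, compound 4 `O=C1c2ccccc2C(=O)N1C/C=C/Cn1cc(C#CCCc2ccccc2)c(=O)[nH]c1=O`, carries phenethyl in place of 4-pentylphenyl on a triple-bonded carbon. The closest measured change is a 2.3-fold lower number from compound 2 to compound 3 (0.36 log units; beyond the scatter), which also alters the group on a triple-bonded carbon and removes a 4-pentylphenyl-free chain. The change an at least 3.8-fold lower number from compound 1 to compound 3 (0.58 log units; beyond the scatter) points the same way, while an at least 1.6-fold lower number from compound 1 to compound 2 (0.22 log units; that floor lies within the scatter) has a floor that does not separate the chains. Within the data shown here, compound 4 loses the 4-pentylphenyl group that is present in the lowest number so far, so a modest move back towards the value of compound 2 is expected. The expected step is a 2.1-fold higher number from compound 3 to compound 4 (0.33 log units; beyond the scatter) in this assay here. For compound 4 the estimated value is 55000 nM, with an expected range from 22000 nM to 100000 nM here.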

Compound 4, half-maximal inhibitory concentration: 27000 nM
Estimate against measurement, compound 4: 2.0-fold (0.31 log units) above, and the stated range covers the measured number.
By their numbers in this assay, from the lowest: compounds 3 and 4 (each within the scatter of the next); then compound 2. At a limit, above all of these: compound 1.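

In this assay, phenethyl in place of 4-pentylphenyl on a triple-bonded carbon gives a 1.0-fold higher number from compound 3 to compound 4 (0.02 log units; within the scatter), so the two groups are not told apart here, and the pentyl part of compound 3 is not needed to hold its level. Both groups carry a six-membered aromatic ring of carbon only, and against the open chain of compound 2, phenyl in place of propyl gives a 2.2-fold lower number from compound 2 to compound 4 (0.35 log units; beyond the scatter), which agrees with the step to compound 3 and has no counterexample among the four compounds. With phenyl in place of hexyl the step is only a floor, an at least 3.7-fold lower number from compound 1 to compound 4 (0.56 log units; beyond the scatter), and compound 1 stands at a limit: the limit of > 100000 nM in this assay, at which 1 of the 4 values shown sits.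

On these data alone, whether an amine or a carboxylic acid on the phenyl ring would shift the number remains open. So does the effect of a longer chain between the ring and the triple-bonded carbon.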